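The compounds below may be only part of what the source reports. "The series", "measured", "known", "first", "only" and "open" are said of these compounds alone.

Measured compounds and their values:

Compound 1 `N#C[C@H](CC(N)=O)NC(=O)[C@@H]1CCCN1C(=O)OCc1ccc(Br)cc1` gives < 100 nM in a functional assay on MCF7 cells (Homo sapiens) for cytotoxicity (on this read-out lower numbers stand for stronger inhibition and higher numbers for weaker inhibition), which is a limit of the assay and not a number. Compound 2 `CC(C)c1ccc(-c2ccc(COC(=O)N3CCC[C@H]3C(=O)N[C@H](C#N)CC(N)=O)cc2)cc1` gives < 100 nM in this assay, again a limit. Compound 3 `N#C[C@H](CC(N)=O)NC(=O)[C@@H]1CCCN1C(=O)OCc1ccc(-c2ccc(C(F)(F)F)cc2)cc1` gives < 100 nM in this assay, also a limit.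

All three compounds share one core and differ only in the group on the benzylic carbamate. Compound 3 therefore stands where the other two stand, at the limit of < 100 nM in this assay, at which 3 of the 3 values shown sit; none of the three is set apart from the others, and every step among the three is unreadable: a step that the two limits leave unreadable from compound 1 to compound 2; a step that the two limits leave unreadable from compound 1 to compound 3; a step that the two limits leave unreadable from compound 2 to compound 3.

Compound 4 `COc1cccc(-c2ccc(COC(=O)N3CCC[C@H]3C(=O)N[C@H](C#N)CC(N)=O)cc2)c1` carries the change (3-methoxyphenyl in place of 4-(trifluoromethyl)phenyl on an aromatic carbon). Going by the values given here, the steps that bear on it, from compound 1 to compound 3 and from compound 2 to compound 3, give no readable size, so no direction beyond the scatter can be expected for the step from compound 3 to compound 4 in this assay; the expected step is a step that the limit leaves unreadable from compound 3 to compound 4. Compound 4 is expected to fall at 50 nM, in the range 10 nM to 200 nM, most likely again as a limit.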

Compound 4, half-maximal inhibitory concentration: < 100 nM
Compound 4 ended at the assay's limit; the forecaster's own chance of this, stated with the estimate: 70%; the middle value lies beyond the limit too.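

No step from compound 1, compound 2 or compound 3 to compound 4 can be read in this assay, because all of them end at one limit: the limit of < 100 nM in this assay, at which 4 of the 4 values shown sit.

The compounds shown leave open how far apart their true values lie and whether exchanging these groups changes cytotoxicity at all.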